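Fluoro added to compound 2: working notes

The compounds below may be only part of what the source reports. "The series", "measured", "known", "first", "only" and "open" are said of these compounds alone.

Measured so far in a functional assay on the whole organism with Rattus norvegicus as the target; a higher number here means that more compound is needed for the effect, a lower number that less compound is needed
- Compound 1 `O=C(O)c1cc(-c2ccc(F)cc2)ccc1O` gives 14 mg/kg
- Compound 2 `Cc1cc(-c2ccccc2)cc(C(=O)O)c1O` gives 60 mg/kg

Compound 2 has the higher number of the two, and its gap to compound 1 lies beyond the scatter. Compound 3 `Cc1cc(-c2ccc(F)cc2)cc(C(=O)O)c1O` is compound 2 with fluoro in place of hydrogen on an aromatic carbon. Going by the values given here, no measured step isolates this change. Among the compounds with values here, compound 1 also carries fluoro and gives 14 mg/kg in this assay as the only guide, which suggests a modest fall in the number. The expected size is an estimated 2.0-fold lower number from compound 2 to compound 3 (0.30 log units; within the scatter) and may not clear the scatter. Compound 3 is expected at 30 mg/kg (estimated range 11 mg/kg to 70 mg/kg).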

Compound 3, dose for half-maximal effect: 60 mg/kg
Estimate against measurement, compound 3: 2.0-fold (0.30 log units) below; low and high end bracket the measured number.
By their numbers in this assay, from the lowest: compound 1; then compounds 2 and 3 (each within the scatter of the next).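

In this assay fluoro in place of hydrogen on an aromatic carbon, para to a large group, gives no change at the digits printed from compound 2 to compound 3 (within the scatter) and so has no readable effect with the methyl present. Going by these compounds alone, the other change, a methyl group taking the place of a hydrogen, gives a 4.3-fold higher number from compound 1 to compound 3 (0.63 log units; beyond the scatter) and is the only step here beyond the scatter. No measurement at hand accounts for either step.
From the compounds shown here alone, whether methyl gives the same step without fluoro remains open. So does the outcome of chloro or methoxy at the fluoro position, or of an ethyl chain in place of the methyl.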